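Removing the Remaining Acetyl from a Silyl-Protected Lactone

A few compounds are considered here, and "the series" means these few. Any claim that something is new, unique, unknown or untested is made for them only; others in the source may bear on it.

Among the measured compounds shown here, compound 3 `C=C1CC[C@@H]2[C@](C)(CO[Si](C)(C)C(C)(C)C)[C@H](O)CC[C@@]2(C)[C@@H]1C/C=C1/C(=O)OC[C@H]1OC(C)=O` stands second highest of the three numbers so far in a functional assay on Col2 cells (Homo sapiens) for cytotoxicity, read by sulforhodamine B assay (a higher number here means that more compound is needed for the effect, a lower number that less compound is needed), where compound 3 gives 8.94 uM. Compound 1 `C=C1CC[C@@H]2[C@](C)(CO)[C@H](OC(C)=O)CC[C@@]2(C)[C@@H]1C/C=C1/C(=O)OC[C@H]1OC(C)=O` gives 10.2 uM in this assay, and the gap between compound 1 and compound 3 lies within the scatter. Compound 2 `C=C1CC[C@@H]2[C@](C)(CO[Si](C)(C)C(C)(C)C)[C@H](OC(C)=O)CC[C@@]2(C)[C@@H]1C/C=C1/C(=O)OC[C@H]1OC(C)=O` gives 2.23 uM in this assay, the lowest of the three numbers. The two measured steps are a 4.6-fold lower number from compound 1 to compound 2 (0.66 log units; beyond the scatter) and a 4.0-fold higher number from compound 2 to compound 3 (0.60 log units; beyond the scatter).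

Compound 4 `C=C1CC[C@@H]2[C@](C)(CO[Si](C)(C)C(C)(C)C)[C@H](O)CC[C@@]2(C)[C@@H]1C/C=C1/C(=O)OC[C@H]1O` differs from compound 3 in one place: hydrogen in place of acetyl on an oxygen on a saturated carbon, on an oxygen on a saturated carbon whose other neighbour is a saturated ring carbon; cut one bond further out, the change reads acetoxy to hydroxy. For the measured compounds named here, only the step from compound 2 to compound 3 is the same kind of exchange, and it raised the number by a modest step in this assay, though at a different oxygen. A modest rise is therefore the expectation for this step too. Compound 4 is expected to give 18 uM in this assay, with a range from 6 uM to 50 uM. The expected step is a 2.0-fold higher number from compound 3 to compound 4 (0.30 log units; within the scatter).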

Compound 4, concentration for half-maximal effect: 17.1 uM
For compound 4 the middle estimate is 1.1-fold (0.02 log units) above the measured one; low and high end bracket the measured number.
By their numbers in this assay, from the lowest: compound 2; then compounds 3, 1 and 4 (each within the scatter of the next).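

In this assay, the exchange of acetoxy to hydroxy on this oxygen, whose carbon's other neighbour is a saturated ring carbon, gives a 1.9-fold higher number from compound 3 to compound 4 (0.28 log units; within the scatter), so the two compounds cannot be told apart at this position. Among the compounds shown here, the same kind of exchange at the other oxygen gave a 4.0-fold higher number from compound 2 to compound 3 (0.60 log units; beyond the scatter), so the earlier compounds showed a step beyond the scatter, whereas this position shows none. Nothing available here bears on the reason for this reading.

Acetoxy and hydroxy are the only groups shown on this oxygen, so it remains open how an amine or a longer acyl chain there would read. On these data alone, it also remains open whether the same exchange would read alike with the other oxygen still carrying its acetyl.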